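The source may hold more compounds than are shown below. What is called first, only, known or untested is meant among the compounds shown, and "the series" means these compounds.

Series notes. Within the data shown here, compound 1 `O=C(/C=C/c1cccc(Br)c1)c1cccc(-c2cccc(F)c2)c1` is one of two compounds with a number so far in a functional assay on HepG2 cells (Homo sapiens) for cytotoxicity, read by sulforhodamine B assay, with a stated time of 48 h; on this read-out lower numbers stand for stronger inhibition and higher numbers for weaker inhibition. In this assay compound 1 gives 6980 nM, the highest of the two numbers. Among the measured compounds shown here, the other measured compound, compound 2 `COc1ccc(/C=C/C(=O)c2ccc(N)c(-c3ccc(OC)c(OC)c3)c2)c(OC)c1`, differs from compound 1 in several places at once, and in this assay compound 2 gives 2130 nM, a lower number beyond the scatter; no single-point step connects the two, so the pair shows only that a lower number is reachable.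

Compound 3 `COc1ccccc1/C=C/C(=O)c1cccc(-c2cccc(F)c2)c1` is unmeasured and differs from compound 1 in one place: 2-methoxyphenyl in place of 3-bromophenyl on a double-bonded chain carbon bound to a double-bonded chain carbon. The rest of the structure is unchanged. For the measured compounds named here, no measured step in this assay covers this change. The step expected from compound 1 to compound 3 is a 1.2-fold lower number from compound 1 to compound 3 (0.07 log units; within the scatter), modest and not clearly beyond the scatter. For compound 3 the estimate in this assay is 6000 nM, with a range from 2500 nM to 14000 nM.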

Compound 3, half-maximal inhibitory concentration: 15400 nM
The estimate for compound 3 lay 2.6-fold (0.41 log units) below the measured number; measured number above the stated range.
By their numbers in this assay, from the lowest: compound 2; then compound 1; then compound 3.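

Among these compounds, this is the first single-place step, and it shows that the group on this double-bonded chain carbon affects the read-out: in this assay, 2-methoxyphenyl in place of 3-bromophenyl gives a 2.2-fold higher number from compound 1 to compound 3 (0.34 log units; beyond the scatter), a move towards weaker inhibition. The earlier pair differed in several places at once and could assign nothing to this position. No measurement in hand bears on why the number rises.

This one exchange removes the bromine and brings in the methoxy group together, so the compounds shown do not separate the contribution of either group. Also open, as far as these compounds go, is whether a hydroxyl or a carboxylic acid on the phenyl ring at this place would give a number lower than that of compound 1.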